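The source may report more compounds than this note shows. Statements on the series, on what has been measured and on what is new or still open speak of the compounds shown alone.

Measured so far in an assay for inhibition of ectonucleoside triphosphate diphosphohydrolase 8 (Homo sapiens), read by malachite green, with a stated time of 10 min; a lower number here means a stronger inhibitor, a higher number a weaker inhibitor:
compound 1, `FC(F)(F)c1nc2c(Br)cccc2c(Cl)c1Br`: > 300000 nM (a limit of the assay)
compound 2, `Fc1ccc(-c2c(C(F)(F)F)nc3c(-c4ccc(F)cc4)cccc3c2-c2ccc(F)cc2)cc1`: > 300000 nM (a limit of the assay)

Compound 1 stands at a limit and nowhere on a numerical scale. Compound 2 likewise gives only a limit. Both values shown sit at the limit of > 300000 nM in this assay, at which 2 of the 2 values shown sit, so no ordering between compound 1 and compound 2 can be drawn. Compound 3 `COc1ccc(-c2cccc3c(Cl)c(Br)c(C(F)(F)F)nc23)cc1` differs from compound 1 by 4-methoxyphenyl in place of bromo on an aromatic carbon. Among the compounds with values here, no step between measured compounds is available for this change; compound 2, which carries aryl groups on the shared core, also reaches only the limit, giving no ground to expect a gain. The step from compound 1 to compound 3 is expected to be an at least 1.2-fold lower number from compound 1 to compound 3 (0.07 log units; that floor lies within the scatter), none beyond the scatter. Compound 3 is estimated at 250000 nM, within 50000 nM to 1000000 nM.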

Compound 3, half-maximal inhibitory concentration: > 300000 nM
Compound 3 ended at the assay's limit; the forecaster's own chance of this, stated with the estimate: 70%; at least 1.2-fold (0.07 log units) between middle value and limit.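

No step can be read from compound 1 to compound 3, as both stay at a limit of the assay: the limit of > 300000 nM in this assay, at which 3 of the 3 values shown sit.
The compounds shown leave open whether any change on the shared core brings a value inside the measurable range.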